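Cyclopentyl for tert-butyl: tolerance in cells stays unreadable

This account rests on a few compounds, and the source may have more. Where it says the series, first, only, none or still open, it means among the compounds named here.

Compound 1 `COc1cc2cc(C#N)ccc2c(OC)c1Oc1cc(NC(C)C)nc(Nc2ccc(C#N)cc2)n1`: > 125000 nM
Compound 2 `COc1cc2cc(C#N)ccc2c(OC)c1Oc1cc(NC(C)(C)C)nc(Nc2ccc(C#N)cc2)n1`: > 125000 nM
Compound 3 `COc1cc2cc(C#N)ccc2c(OC)c1Oc1cc(NCCCOC(C)C)nc(Nc2ccc(C#N)cc2)n1`: > 125000 nM

Of the compounds shown here, three sharing one core have been tested in an ADME assay on MT4 cells (Homo sapiens) for cytotoxicity, read by MTT assay, with a stated time of 5 days; a lower number here means that less compound is tolerated, a higher number that more compound is tolerated. Compound 2 `COc1cc2cc(C#N)ccc2c(OC)c1Oc1cc(NC(C)(C)C)nc(Nc2ccc(C#N)cc2)n1` reaches only a limit of the assay, > 125000 nM, so no number is known for it. The same holds for compound 1 and for compound 3, as the limit of > 125000 nM in this assay, at which 3 of the 3 values shown sit, shows. The steps among them, a step that the two limits leave unreadable from compound 1 to compound 2, a step that the two limits leave unreadable from compound 1 to compound 3 and a step that the two limits leave unreadable from compound 2 to compound 3, are therefore unreadable: none of the three tells whether a change on the nitrogen on an aromatic ring moves tolerance at all.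

Compound 4 `COc1cc2cc(C#N)ccc2c(OC)c1Oc1cc(NC2CCCC2)nc(Nc2ccc(C#N)cc2)n1` is the next to be measured. It differs from compound 2 by cyclopentyl in place of tert-butyl on a nitrogen on an aromatic ring. Going by the values given here, the earlier steps give no direction and no size; the only thing seen is that every change at this place so far has left the value at the limit. The expected step is therefore a number no higher from compound 2 to compound 4 (the limit leaves the size open), that is, none beyond the scatter. Compound 4 is expected to give about 125000 nM, within 60000 nM to 125000 nM, most likely again as a limit.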

Compound 4, half-maximal cytotoxic concentration: > 125000 nM
Compound 4: no number, only a limit; the forecaster's own chance of this, stated with the estimate: 85%; the middle value sits exactly at the limit.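

In this assay compound 4 gives > 125000 nM, which is a limit and not a number. Its steps to compound 1, compound 2 and compound 3 therefore cannot be read: the limit of > 125000 nM in this assay, at which 4 of the 4 values shown sit. The compounds shown leave open whether any change on the nitrogen on an aromatic ring moves tolerance at all.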